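Chloro in place of fluoro: working notes

This account rests on a few compounds, and the source may have more. Where it says the series, first, only, none or still open, it means among the compounds named here.

In an ADME assay on microsomes from liver (Homo sapiens) for metabolic stability (a higher number here means that the compound lasts longer, a lower number that the compound disappears faster), compound 1 `CC#C[C@@H](Cc1nnn[nH]1)c1ccc(OCc2ccc3sc(F)c(-c4ccccc4C)c3c2)cc1` gives 0.0667 h, the lowest of the three numbers in hand. Compound 3 `CC#C[C@@H](Cc1nnn[nH]1)c1ccc(OCc2ccc3scc(-c4cncnc4C)c3c2)cc1` gives 0.233 h and compound 2 `CC#C[C@@H](Cc1nnn[nH]1)c1ccc(OCc2ccc3sc(F)c(-c4ccc(OCCOC)cc4C)c3c2)cc1` gives 1.95 h, both beyond the scatter from compound 1.

Compound 4 `CC#C[C@@H](Cc1nnn[nH]1)c1ccc(OCc2ccc3sc(Cl)c(-c4ccccc4C)c3c2)cc1` has not yet been measured. It departs from compound 1 in one place: chloro in place of fluoro on an aromatic carbon. This is chloro in place of fluoro on an aromatic carbon of the five-membered aromatic ring with 1 sulfur, next to the ring sulfur.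

For the measured compounds named here, only one measured step changes a single place: a 29-fold higher number from compound 1 to compound 2 (1.47 log units; beyond the scatter). That large step comes from 2-methoxyethoxy in place of hydrogen on an aromatic carbon, a different change at a different place, so it gives no size for this exchange. Compound 3 carries no fluoro, but it also differs from compound 1 in its other aryl group, so compound 3 at 0.233 h does not isolate the halogen. Going by the values given here, no measured pair exchanges one halogen for another, so no step beyond the scatter is expected. The estimated step is a 1.2-fold higher number from compound 1 to compound 4 (0.08 log units; within the scatter). For compound 4 the estimated half-life is 0.08 h, with an expected range of 0.035 h to 0.2 h.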

Compound 4, half-life: 0.175 h
Beside the measured number, compound 4's estimate is 2.2-fold (0.34 log units) below it, within the range that was stated.
By their numbers in this assay, from the lowest: compound 1; then compounds 4 and 3 (each within the scatter of the next); then compound 2.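

In this assay, chloro in place of fluoro on the aromatic carbon next to the ring sulfur gives a 2.6-fold higher number from compound 1 to compound 4 (0.42 log units; beyond the scatter), so this position responds to the identity of the halogen alone, with no ring added and no hydrogen-bond donor or acceptor entering or leaving. For the compounds shown here, the earlier compounds could not show this: their only single-place step, a 29-fold higher number from compound 1 to compound 2 (1.47 log units; beyond the scatter), comes from 2-methoxyethoxy in place of hydrogen at another place, so the sensitivity of the halogen position is new, though its step is modest beside that large one. No measurement in hand gives a reason for the halogen step, which stands here as an observation only.

Open, from the compounds shown here alone, is whether the step from fluoro to chloro holds with the 2-methoxyethoxy group present on the 2-methylphenyl group, or whether the two changes together give less or more than each alone. Also open, going by these compounds, is how bromo, nitrile or plain hydrogen at this same carbon would rank against fluoro and chloro on the core of compound 1.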